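From Benzyl to Phenyl on the Amide Nitrogen

The source may hold more compounds than are shown below. What is called first, only, known or untested is meant among the compounds shown, and "the series" means these compounds.

This short series shares one core, shown in compound 2 `COc1ccc2c(=O)c(/C=C/C(=O)NCc3ccccc3)coc2c1`. In a functional assay on Huh-7 cells (Homo sapiens) for inhibition, read by MTT assay, with a stated time of 48 h (on this read-out lower numbers stand for stronger inhibition and higher numbers for weaker inhibition), compound 2 gives 13600 nM. Compound 1 `COc1ccc2c(=O)c(/C=C/C(=O)Nc3cccc(Cl)c3)coc2c1` carries a 3-chlorophenyl group on the same amide-type nitrogen. In this assay compound 1 reaches only a limit, > 100000 nM. Compound 1 thus sits at the limit of > 100000 nM in this assay, at which 1 of the 2 values shown sits. Among the two results shown, compound 2 holds the only true number, the other result being a limit. The measured step between them is an at least 7.3-fold lower number from compound 1 to compound 2 (0.86 log units; beyond the scatter).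

Compound 3 `COc1ccc2c(=O)c(/C=C/C(=O)Nc3ccccc3)coc2c1` differs from compound 2 by phenyl in place of benzyl on an amide-type nitrogen. Going by the values given here, the one measured step that bears on this change is an at least 7.3-fold lower number from compound 1 to compound 2 (0.86 log units; beyond the scatter), which ran in the opposite direction from the change compound 3 undergoes and was at least modest, so moving back from benzyl toward phenyl is expected to raise the number in this assay. Compound 3 is therefore estimated at 50000 nM, between 15000 nM and 150000 nM. That estimate amounts to a 3.7-fold higher number from compound 2 to compound 3 (0.57 log units; beyond the scatter), with a real chance that only a limit is reported.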

Compound 3, half-maximal inhibitory concentration: 9050 nM
Estimate against measurement, compound 3: 5.5-fold (0.74 log units) above; measured number below the stated range.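

In this assay, phenyl in place of benzyl on the amide-type nitrogen gives a 1.5-fold lower number from compound 2 to compound 3 (0.18 log units; within the scatter), so compounds 2 and 3 cannot be told apart here, and the single carbon that separates these two groups makes no visible difference. The large change lies elsewhere on the molecule: hydrogen in place of chloro on an aromatic carbon gives an at least 11-fold lower number from compound 1 to compound 3 (1.04 log units; beyond the scatter), so the earlier gain seen on going from compound 1 to compound 2 now looks tied to losing the chloro group, not to gaining the benzyl group. Compound 1 gives no true number, only a limit, so the real size of both steps that start from it stays unknown: the limit of > 100000 nM in this assay, at which 1 of the 3 values shown sits.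

The compounds shown do not tell whether a chloro group on the benzyl ring of compound 2 would raise the number as it does on the phenyl ring, or whether a fluoro, methoxy or amine group on that same aromatic carbon would behave like chloro or like hydrogen. They also leave open what a longer chain such as phenethyl, or a cyclohexyl group, would do on the amide-type nitrogen.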